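The compounds below may be only part of what the source reports. "The series", "measured", "known", "first", "only" and "open" are said of these compounds alone.

Compound 2 `CC(C)=CCc1cc(C2=C(O)/C(=C/c3ccc(O)c(CC(O)C(C)(C)O)c3)OC2=O)c(O)cc1O` stands at the higher of the two numbers recorded so far in a functional assay on J774.1 cells (Mus musculus), read by LDH release, with a stated time of 1 h, in the presence of a further agent that is not named here; a higher number here means a weaker inhibitor, a lower number a stronger inhibitor: compound 2 gives 7400 nM, and compound 1 `CC(C)=CCc1cc(C2=C(O)/C(=C/c3ccc4c(c3)CC(O)C(C)(C)O4)OC2=O)c(O)cc1O` gives 2800 nM. Compound 3 `CC(C)=CCc1cc(C2=C(O)/C(=C/c3ccc(O)c(CCC(C)(C)O)c3)OC2=O)c(O)cc1O` has not yet been measured. Compound 3 differs from compound 2 by hydrogen in place of hydroxy on a saturated chain carbon bound to two saturated chain carbons, so that 2,3-dihydroxy-3-methylbutyl becomes 3-hydroxy-3-methylbutyl. For the measured compounds named here, no measured pair shows this change, so only a small step is expected, within the scatter or leaning toward a lower number. The expected step is a 1.5-fold lower number from compound 2 to compound 3 (0.17 log units; within the scatter). Compound 3 is therefore estimated at 5000 nM, with a range from 2000 nM to 12000 nM.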

Compound 3, half-maximal inhibitory concentration: 3100 nM
For compound 3 the middle estimate is 1.6-fold (0.21 log units) above the measured one, and the stated range covers the measured number.
By their numbers in this assay, from the lowest: compounds 1 and 3 (each within the scatter of the next); then compound 2.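

In this assay, replacing the hydroxy on this saturated chain carbon with hydrogen gives a stronger inhibitor (a 2.4-fold lower number from compound 2 to compound 3 (0.38 log units; beyond the scatter)). The change from 2,3-dihydroxy-3-methylbutyl to 3-hydroxy-3-methylbutyl therefore shows that this hydroxy is not required for inhibition here, and that this chain position responds to a single-atom edit. Nothing available here accounts for the gain.

On these data alone, whether the remaining hydroxy on the chain matters stays open. So does the effect of an amine or a carboxylic acid at this carbon, or of a longer chain.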